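Swapping the Aryl Group of a Sulfonate Ester Series

The compounds below may be only part of what the source reports. "The series", "measured", "known", "first", "only" and "open" are said of these compounds alone.

Compound 1 `CCc1ccccc1OS(=O)(=O)c1ccc(N2CCN(C)C2=O)cc1`: 2300 nM
Compound 2 `CCN1CCN(c2ccc(S(=O)(=O)Oc3ccc(OC)cc3)cc2)C1=O`: 26000 nM
Compound 3 `CCCN1CCN(c2ccc(S(=O)(=O)Oc3ccccc3CC)cc2)C1=O`: > 50000 nM

In a functional assay on M21 cells (Homo sapiens) for antiproliferative activity, read by sulforhodamine B assay, with a stated time of 48 h (on this read-out higher numbers stand for weaker inhibition and lower numbers for stronger inhibition), compound 1 gives 2300 nM. Compound 2 gives 26000 nM in this assay. For compound 3 this assay reports only a limit, > 50000 nM, so compound 3 stands at the weak end of the three, without a number of its own. Within the data shown here, the one step measured in this set, an at least 21-fold higher number from compound 1 to compound 3 (1.33 log units; beyond the scatter), concerns a change elsewhere in the molecule and touches the limit (the limit of > 50000 nM in this assay, at which 1 of the 3 values shown sits). Compound 4 `CCCN1CCN(c2ccc(S(=O)(=O)Oc3ccc(Cl)cc3)cc2)C1=O` differs from compound 3 at the oxygen bound to the sulfonyl sulfur: 4-chlorophenyl in place of 2-ethylphenyl on an oxygen. Among the measured compounds shown here, no measured step matches this change, so its effect cannot be sized from the data. Compound 4 is therefore expected near 30000 nM (range 7000 nM to 120000 nM), meaning an expected step of an at least 1.6-fold lower number from compound 3 to compound 4 (0.22 log units; that floor lies within the scatter).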

Compound 4, half-maximal inhibitory concentration: 34000 nM
Compound 4: the middle estimate sits 1.1-fold (0.05 log units) below what was measured; measured number inside the range.
By their numbers in this assay, from the lowest: compound 1; then compounds 2 and 4 (each within the scatter of the next). At a limit, above all of these: compound 3.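

In this assay, 4-chlorophenyl in place of 2-ethylphenyl on an oxygen gives an at least 1.4-fold lower number from compound 3 to compound 4 (0.16 log units; that floor lies within the scatter), the first step measured at this position. With the rest of the molecule unchanged, the swap yields a measured number, though that floor alone does not establish a change beyond the scatter. Compound 3 stands at a limit, so the full size of the step cannot be read: the limit of > 50000 nM in this assay, at which 1 of the 4 values shown sits.

Still open, going by these compounds, is how an amine or a carboxylic acid would compare with 4-chlorophenyl on this oxygen. Also open, on these data alone, is whether 4-chlorophenyl would give a similar number on the core of compound 1.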